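Aryl swap at the terminal ring: cytotoxicity working notes

The source may report more compounds than this note shows. Statements on the series, on what has been measured and on what is new or still open speak of the compounds shown alone.

Compound 1 `CC(C)N(Cc1cccc(OCCCCCC(=O)O)c1)C(=O)c1ccc(-c2cccc(-c3ccccc3)c2)cc1` and compound 2 `CC(C)N(Cc1cccc(OCCCCCC(=O)O)c1)C(=O)c1ccc(-c2ccsc2)cc1` share one core and differ at a single aromatic carbon. In an ADME assay on HEK293 cells (Homo sapiens) for cytotoxicity, read by CellTiter-Glo and resazurin assay, with a stated time of 72 h (a higher number here means that more compound is needed for the effect, a lower number that less compound is needed), compound 1 sits at a limit of > 26000 nM. In this assay compound 2 also sits at a limit of > 26000 nM. The step that the two limits leave unreadable from compound 1 to compound 2 cannot be read from two limits (the limit of > 26000 nM in this assay, at which 2 of the 2 values shown sit). Compound 3 `COc1cc(OC)cc(-c2ccc(C(=O)N(Cc3cccc(OCCCCCC(=O)O)c3)C(C)C)cc2)c1` arises from compound 2 by 3,5-dimethoxyphenyl in place of thiophen-3-yl on an aromatic carbon. Within the data shown here, only that unreadable step bears on this change, so no shift beyond the scatter is predicted. Compound 3 is expected to stay near the limit, an estimated 40000 nM (range 15000 nM to 100000 nM) in this assay. The expected step that the limit leaves unreadable from compound 2 to compound 3 is estimated to lie within the scatter.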

Compound 3, half-maximal effective concentration: > 26000 nM
Compound 3: only a limit was reported; the forecaster's own chance of this, stated with the estimate: 85%; the middle value is on the limit's open side.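

Compound 3 also reports only a limit, so no step among compound 1, compound 2 and compound 3 can be read: the limit of > 26000 nM in this assay, at which 3 of the 3 values shown sit.

The compounds shown leave open how these aryl swaps rank in this assay, since none gives a measured half-maximal effective concentration.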